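The source may hold more compounds than are shown below. What is called first, only, known or untested is meant among the compounds shown, and "the series" means these compounds.

Measured compounds:
Compound 1, `COc1cc(Oc2cccc(Nc3ccccc3)c2)cc(OC)c1CNCc1ccccc1`: 4070 nM in a functional assay on HCT-116 cells (Homo sapiens) for inhibition, read by MTT assay, with a stated time of 72 h; a higher number here means a weaker inhibitor, a lower number a stronger inhibitor
Compound 2, `COc1cc(Oc2cccc(Nc3ccccc3)c2)cc(OC)c1CN(C)C`: 12900 nM in this assay

Going by the values given here, compound 2 gives the highest of the two numbers; its nearest neighbour is compound 1, and the only measured step, a 3.2-fold higher number from compound 1 to compound 2 (0.50 log units; beyond the scatter), separates them. Compound 3, `COc1cc(Oc2cccc(Nc3ccccc3)c2)cc(OC)c1CNCc1ccc(Br)cc1`, has not been measured. It differs from compound 2 by (4-bromobenzyl)amino in place of dimethylamino on a saturated chain carbon bound to an aromatic carbon. Among the compounds with values here, this change largely reverses the one measured step: the benzylamino group that compound 1 carried returns, now with a bromine on its ring. That step was modest and beyond the scatter, so a step of similar size in the opposite direction is expected here, bringing compound 3 close to compound 1. Compound 3 is therefore estimated at 3500 nM, within 1200 nM to 10000 nM, which means an expected 3.7-fold lower number from compound 2 to compound 3 (0.57 log units; beyond the scatter).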

Compound 3, half-maximal inhibitory concentration: 6230 nM
The estimate for compound 3 lay 1.8-fold (0.25 log units) below the measured number; the measured number falls inside the stated range.
By their numbers in this assay, from the lowest: compounds 1 and 3 (each within the scatter of the next); then compound 2.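

In this assay, the lower number that comes with a benzylamino-type group over dimethylamino holds when that group carries a bromine: (4-bromobenzyl)amino in place of dimethylamino gives a 2.1-fold lower number from compound 2 to compound 3 (0.32 log units; beyond the scatter), a modest step. Bromo in place of hydrogen on an aromatic carbon gives a 1.5-fold higher number from compound 1 to compound 3 (0.18 log units; within the scatter), so at this position the bromine cannot be told apart from hydrogen in this cell assay. No evidence on the cause of either step is at hand.

The compounds shown leave open whether a methoxy group or a carboxylic acid at the place of the bromine would also leave the number unchanged. They also leave open whether the aromatic ring or the amine hydrogen goes with the lower numbers, a question that an N-methyl-N-benzylamino group could help to separate.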